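The compounds below may be only part of what the source reports. "The series", "measured", "known", "first", "only" and "open" are said of these compounds alone.

Measured compounds in this series:
Compound 1 `O=C(O)CCCOc1ccc(-c2nc3ncccn3c2NC2CCCCC2)cc1`: in a toxicity assay on A549 cells (Homo sapiens) for cytotoxicity, read by luminescence and CellTiter-Glo, with a stated time of 48 h (on this read-out lower numbers stand for higher toxicity in this test and higher numbers for lower toxicity in this test), compound 1 returns only a limit of the assay, > 100000 nM.
Compound 2 `COCCOc1ccc(-c2nc3ncccn3c2NC2CCCCC2)cc1`: in this assay compound 2 likewise returns only a limit of the assay, > 100000 nM.
Compound 3 `Fc1ccc(-c2nc3ncccn3c2NC2CCCCC2)cc1`: in this assay compound 3 gives 100000 nM.

Among the measured compounds shown here, compound 3 thus holds the only number so far in this assay; the two other values are limits, both sitting at the limit of > 100000 nM in this assay, at which 2 of the 3 values shown sit. The measured steps all concern the substituent on the phenyl ring opposite the shared core: a number no higher from compound 1 to compound 3 (the limit leaves the size open), a number no higher from compound 2 to compound 3 (the limit leaves the size open), and a step that the two limits leave unreadable from compound 1 to compound 2. None of these is readable in size, and none exchanges one halogen for another.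

Compound 4 `Clc1ccc(-c2nc3ncccn3c2NC2CCCCC2)cc1` differs from compound 3 by chloro in place of fluoro on an aromatic carbon. For the measured compounds named here, no measured step bears directly on a halogen swap, so the three measured compounds give no direction for this change; what they show is that this end of the molecule has so far been varied without any readable movement in this assay. For compound 4 the step is therefore expected to be no change at the digits printed from compound 3 to compound 4 (within the scatter), not beyond the scatter. Compound 4 is estimated at 100000 nM, with a range of 40000 nM to 250000 nM, and a substantial chance that the assay again reports only a limit.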

Compound 4, half-maximal cytotoxic concentration: > 100000 nM
Compound 4: no number, only a limit (the forecaster's own chance of this, stated with the estimate: 50%); the middle value lies on the limit itself.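

Chloro in place of fluoro, on an aromatic carbon para to a large group, gives in this assay a number no lower from compound 3 to compound 4 (the limit leaves the size open). Among the compounds shown here, this is the first halogen exchange seen at this position, and it produces no lower number, so compound 3 remains the only compound with a readable value and the 4-chlorophenyl compound joins the alkoxy-bearing compounds at the edge of the assay range: the limit of > 100000 nM in this assay, at which 3 of the 4 values shown sit. The steps from compound 1 and from compound 2 to compound 4 cannot be read, as both ends of each are limits.

On these data alone, the size of the fluoro to chloro step stays open, and so does the true spread among the four compounds, since only one of them has a number. As far as these compounds go, whether bromo, trifluoromethyl, an amine or a longer chain on this aromatic carbon would give a clearly lower number in this assay also remains open, as does the effect of any change away from this position, such as replacing the cyclohexyl group.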